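This account rests on a few compounds, and the source may have more. Where it says the series, first, only, none or still open, it means among the compounds named here.

Of the compounds shown here, two built on the same shared core have been measured, and a third awaits its result. Compound 1 `Nc1ncn(CCC2(N)OC(=O)C(OCc3ccccc3)=C2OCc2ccccc2)c(=O)n1` was tested in a functional assay on HeLa cells (Homo sapiens) for inhibition, read by MTT assay, with a stated time of 72 h; on this read-out lower numbers stand for stronger inhibition and higher numbers for weaker inhibition. In this assay compound 1 gives > 100000 nM, which is a limit of the assay and not a number. Compound 2 `NC1(CCn2ccc(=O)[nH]c2=O)OC(=O)C(OCc2ccccc2)=C1OCc1ccccc1` carries a different ring on the same chain. In this assay compound 2 gives > 100000 nM, which again is a limit rather than a number. The step between them cannot be sized: a step that the two limits leave unreadable from compound 1 to compound 2. Both values sit at the same limit (the limit of > 100000 nM in this assay, at which 2 of the 2 values shown sit), so compound 2 stands level with compound 1 as far as the numbers reveal, without a readable number of its own.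

Compound 3 `Nc1ccn(CCC2(N)OC(=O)C(OCc3ccccc3)=C2OCc2ccccc2)c(=O)n1` brings the next change: a group of 8 heavy atoms (4 carbon, 3 nitrogen, 1 oxygen; one six-membered aromatic ring with 2 hetero atoms) in place of a group of 8 heavy atoms (4 carbon, 2 nitrogen, 2 oxygen; one six-membered aromatic ring with 2 hetero atoms), on a saturated chain carbon, two bonds along the chain from a saturated ring carbon. Going by the values given here, the only measured step on this part of the molecule is unreadable, so it offers no direction and no size. The expected step is a step that the limit leaves unreadable from compound 2 to compound 3, meaning no change beyond the scatter is anticipated. Compound 3 is expected to give 150000 nM, with a range from 50000 nM to 500000 nM, most probably reported once more as a limit.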

Compound 3, half-maximal inhibitory concentration: > 100000 nM
Compound 3: a limit, no number (the forecaster's own chance of this, stated with the estimate: 85%); the middle value does not contradict the limit.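

Compound 3 also gives a limit and not a number, so no step among compound 1, compound 2 and compound 3 can be read in this assay, and all three stay level as far as the values show: the limit of > 100000 nM in this assay, at which 3 of the 3 values shown sit.

The compounds shown leave open whether any change to the ring on this chain, or elsewhere on the shared core, would give a readable value in this assay and which way it would go.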